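The source may hold more compounds than are shown below. What is called first, only, known or untested is meant among the compounds shown, and "the series" means these compounds.

Of the compounds shown here, three built on one shared core have been tested in a functional assay on SW 1116 cells (Homo sapiens) for cytotoxicity, read by MTT assay, with a stated time of 48 h; a lower number here means a stronger inhibitor, a higher number a weaker inhibitor. Compound 1 `O=C(CSc1nnc(-c2ccncc2)o1)N/N=C/c1ccc(Cl)cc1` gives 17000 nM. Compound 2 `O=C(CSc1nnc(-c2ccncc2)o1)N/N=C/c1ccc(Br)cc1` gives 21300 nM in this assay. The two differ by bromo in place of chloro on an aromatic carbon, and that change made a step of a 1.3-fold higher number from compound 1 to compound 2 (0.10 log units; within the scatter). Compound 3 `O=C(CSc1nnc(-c2ccncc2)o1)N/N=C/c1cc(Cl)ccc1O` gives 5240 nM in this assay; it differs from compound 1 by 5-chloro-2-hydroxyphenyl in place of 4-chlorophenyl on a carbon with a double bond to nitrogen, and the steps toward it were a 3.2-fold lower number from compound 1 to compound 3 (0.51 log units; beyond the scatter) and a 4.1-fold lower number from compound 2 to compound 3 (0.61 log units; beyond the scatter). Compound 4 `O=C(CSc1nnc(-c2ccncc2)o1)N/N=C/c1cc(Br)ccc1O` has not yet been measured. It differs from compound 3 by bromo in place of chloro on an aromatic carbon. Within the data shown here, this is the same kind of change as the one from compound 1 to compound 2, but not the same: there the halogen sat para to a large group, whereas here it sits meta to a large group and para to a hydroxy group. The earlier step of a 1.3-fold higher number from compound 1 to compound 2 (0.10 log units; within the scatter) stayed within the scatter, so for compound 4 the expected step is a 1.2-fold higher number from compound 3 to compound 4 (0.08 log units; within the scatter). Compound 4 is therefore estimated to give 6300 nM in this assay, most likely between 3000 nM and 13000 nM.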

Compound 4, half-maximal inhibitory concentration: 8150 nM
Compound 4: the middle estimate sits 1.3-fold (0.11 log units) below what was measured, and the stated range covers the measured number.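

In this assay, bromo in place of chloro on the hydroxy-bearing ring gave a 1.6-fold higher number from compound 3 to compound 4 (0.19 log units; within the scatter), and this change behaves alike on both cores: the same change on two cores in this assay, a 1.3-fold higher number (0.10 log units; within the scatter) from compound 1 to compound 2 and a 1.6-fold higher number (0.19 log units; within the scatter) from compound 3 to compound 4, 1.2-fold (0.09 log units) apart, within the scatter of two such steps

Moving to the 5-bromo-2-hydroxyphenyl group gave steps beyond the scatter, namely a 2.6-fold lower number from compound 2 to compound 4 (0.42 log units; beyond the scatter) and a 2.1-fold lower number from compound 1 to compound 4 (0.32 log units; beyond the scatter). Among these compounds, two pairs with such small steps show only that this halogen swap carried over between these two cores without a clear change; they cannot show that it would carry over to other cores, or rule out a real difference too small to see above the scatter.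

Still open, on these data alone, is what fluoro or iodo would do in place of the chloro or bromo on these rings. Also open is whether a methoxy or an amino group could stand in place of the hydroxy group, and how any of these compounds would read on other cell lines.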